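Returning to a methoxynaphthalenyl group on the saturated ring carbon

A few compounds are considered here, and "the series" means these few. Any claim that something is new, unique, unknown or untested is made for them only; others in the source may bear on it.

Compound 2 `COc1cc(N2C(N)=C(C#N)C(c3ccccc3Cl)C3=C2CC(C)(C)CC3=O)cc(OC)c1OC` carries a 2-chlorophenyl group on a saturated ring carbon of the shared core. Among the measured compounds shown here, in a functional assay on Ehrlich cells (Mus musculus) for cytotoxicity, tested at 100 ug/mL (on this read-out higher numbers stand for a stronger effect at the one concentration tested and lower numbers for a weaker effect), compound 2 gives 20%, the lower of the two numbers measured so far. For the measured compounds named here, its nearest neighbour is compound 1 `COc1cc(N2C(N)=C(C#N)C(c3ccc(OC)c4ccccc34)C3=C2CC(C)(C)CC3=O)cc(OC)c1OC`, which in this assay gives 40%; the single step between them is a number 20 percentage points lower from compound 1 to compound 2 (beyond the scatter), a change on the saturated ring carbon.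

Compound 3 `COc1cc(N2C(N)=C(C#N)C(c3c(OC)ccc4ccccc34)C3=C2CC(C)(C)CC3=O)cc(OC)c1OC` has not yet been measured. Relative to compound 2 the difference is 2-methoxynaphthalen-1-yl in place of 2-chlorophenyl on a saturated ring carbon, again on the same saturated ring carbon. Going by the values given here, the only step that bears on it is the one from compound 1 to compound 2, where a methoxy-bearing naphthalenyl gave the higher number. Compound 3 is therefore expected to move back up, by about a number 15 percentage points higher from compound 2 to compound 3 (beyond the scatter), as the methoxynaphthalenyl group returns.

Compound 3 is estimated at 35%, within a range from 15% to 55%.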

Compound 3, a percentage reported as activity, at one concentration (the size of the read-out at that concentration, not a potency): 30%
For compound 3 the middle estimate is 5 percentage points above the measured one; measured number inside the range.
By their numbers in this assay, from the lowest: compounds 2, 3 and 1 (each within the scatter of the next, the first and the last beyond it).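

The exchange of 2-chlorophenyl for 2-methoxynaphthalen-1-yl on the saturated ring carbon gives a number 10 percentage points higher from compound 2 to compound 3 (within the scatter) in this assay and so does not separate the two compounds on this read-out. The two methoxynaphthalenyl compounds cannot be separated either, with a number 10 percentage points lower from compound 1 to compound 3 (within the scatter) in the same assay, so carrying a methoxynaphthalenyl group does not by itself set a compound clear of compound 2: compound 1 is clear of it, while compound 3 goes against any such pattern. Nothing given here explains these numbers.

The compounds shown leave open whether a phenyl group carrying an amine or a carboxylic acid on this saturated ring carbon would move the number beyond the scatter in either direction. From the compounds shown here alone, how a change elsewhere on the shared core would act together with this one also stays open.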